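The compounds below may be only part of what the source reports. "The series", "measured", "known", "first", "only" and "open" are said of these compounds alone.

Measured compounds, with their numbers in an ADME assay (liver) for metabolic stability, with Liver microsome (Homo sapiens) as the target, read by LC-MS, using microsomes, tested at 1 uM; a higher number here means faster removal of the compound, a lower number slower removal:
compound 1, `CNc1nc(NCCCN(C)C)c2sc(-c3ccc(OC)nc3)cc2n1`: 10 uL/min
compound 2, `CNc1nc(NCCCN(C)C)c2sc(-c3ccc(C(C)=O)cc3)cc2n1`: 81 uL/min
compound 3, `CNc1nc(NCCCN(C)C)c2sc(-c3ccoc3)cc2n1`: 33.3 uL/min

Compound 3 stands second highest of the three in this assay. Its nearest neighbour is compound 2, a 2.4-fold lower number from compound 2 to compound 3 (0.39 log units; beyond the scatter), and the furthest is compound 1, a 3.3-fold higher number from compound 1 to compound 3 (0.52 log units; beyond the scatter); both steps lie beyond the scatter.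

The unmeasured compound 4 is `CNc1nc(NCCCN(C)C)c2sc(-c3cncnc3)cc2n1`. It differs from compound 3 only at the aryl group on the shared core: pyrimidin-5-yl in place of furan-3-yl on an aromatic carbon.

Going by the values given here, two measured steps bear on this change, since both alter the same group on the same carbon. The step of a 3.3-fold higher number from compound 1 to compound 3 (0.52 log units; beyond the scatter) sets a six-membered ring with one nitrogen against the furan-3-yl, and the furan-3-yl gave the higher number. The step of a 2.4-fold lower number from compound 2 to compound 3 (0.39 log units; beyond the scatter) sets a carbocyclic six-membered ring against the furan-3-yl, and there the furan-3-yl gave the lower number. Only compound 1 carries a ring nitrogen, so the expectation leans on that single step and stays uncertain.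

Compound 4 is therefore expected to give a moderately lower number than compound 3, a 2.1-fold lower number from compound 3 to compound 4 (0.32 log units; beyond the scatter), which is reasoned from compound 1 giving 10 uL/min with its own ring nitrogen. The estimate for compound 4 in this assay is 16 uL/min, within a range of 6 uL/min to 40 uL/min.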

Compound 4, intrinsic clearance in a liver preparation (reported as CLH), per the amount of preparation that the assay uses: < 17 uL/min
Compound 4 was reported as a limit; the forecaster's own chance of this, stated with the estimate: 10%; the middle value does not contradict the limit.
By their numbers in this assay, from the lowest: compound 1; then compound 3; then compound 2.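

In this assay compound 4 is reported as a limit and not as a number: the limit of < 17 uL/min in this assay, at which 1 of the 4 values shown sits. On the aromatic carbon next to the ring sulfur, pyrimidin-5-yl in place of furan-3-yl gives an at least 1.9-fold lower number from compound 3 to compound 4 (0.29 log units; that floor lies within the scatter), so this change is not shown to lie beyond the scatter, although the true step may be larger. The comparison with the carbocyclic ring is firmer at an at least 4.7-fold lower number from compound 2 to compound 4 (0.67 log units; beyond the scatter), which adds a second aryl group with ring nitrogen, after the 6-methoxypyridin-3-yl of compound 1, that stands clear of the 4-acetylphenyl of compound 2, while the step from compound 1 to compound 4 cannot be read.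

The compounds shown leave open how far the true number of compound 4 lies under its limit, and so whether pyrimidin-5-yl differs at all from 6-methoxypyridin-3-yl at this carbon. They also leave open how an unsubstituted phenyl or pyridin-3-yl group would read here, which would separate the ring nitrogen from the methoxy and acetyl groups carried by compound 1 and compound 2.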